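Notes on the series: bromo to fluoro

The source may report more compounds than this note shows. Statements on the series, on what has been measured and on what is new or still open speak of the compounds shown alone.

Measured in an ADME assay on L929 cells (Mus musculus) for cytotoxicity, read by MTT assay, with a stated time of 72 h (on this read-out lower numbers stand for stronger inhibition and higher numbers for weaker inhibition), as follows
compound 1 `CC(=O)c1ccc(/N=C2\C=C(OCc3cn(S(=O)(=O)c4ccc(C)cc4)nn3)C(=O)c3ccccc32)cc1` gives 10800 nM
compound 2 `Cc1ccc(S(=O)(=O)n2cc(COC3=C/C(=N\c4ccc(I)cc4)c4ccccc4C3=O)nn2)cc1` gives > 20000 nM (a limit)
compound 3 `Cc1ccc(S(=O)(=O)n2cc(COC3=C/C(=N\c4ccc(Br)cc4)c4ccccc4C3=O)nn2)cc1` gives > 20000 nM (a limit)

Compound 3 stands at the limit of > 20000 nM in this assay, at which 2 of the 3 values shown sit, and so gives a limit, not a number. Compound 4 `Cc1ccc(S(=O)(=O)n2cc(COC3=C/C(=N\c4ccc(F)cc4)c4ccccc4C3=O)nn2)cc1` differs from it by fluoro in place of bromo on an aromatic carbon and carries fluoro in place of bromo on an aromatic carbon, para to a large group. The nearest measured change, bromo in place of iodo, is a step that the two limits leave unreadable from compound 2 to compound 3 and offers no size to carry over. Iodo in place of acetyl is an at least 1.8-fold higher number from compound 1 to compound 2 (0.26 log units; that floor lies within the scatter) and bromo in place of acetyl is an at least 1.8-fold higher number from compound 1 to compound 3 (0.26 log units; that floor lies within the scatter) and neither floor passes the scatter. No size of change can be read from these steps, so none beyond the scatter is expected for compound 4 in this assay and a further limit is quite possible. The estimated change is a number no higher from compound 3 to compound 4 (the limit leaves the size open) on this reading. For compound 4 the estimated value is 20000 nM with an expected range from 9000 nM to 40000 nM as the working figure.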

Compound 4, half-maximal inhibitory concentration: > 20000 nM
Compound 4 was reported as a limit; the forecaster's own chance of this, stated with the estimate: 60%; the middle value lies on the limit itself.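

In this assay compound 4 gives > 20000 nM, which is a limit and not a number. Fluoro on this aromatic carbon therefore falls with iodo and bromo, and the steps among compound 2, compound 3 and compound 4 cannot be read: the limit of > 20000 nM in this assay, at which 3 of the 4 values shown sit.

Fluoro in place of acetyl gives an at least 1.8-fold higher number from compound 1 to compound 4 (0.26 log units; that floor lies within the scatter), the same floor as iodo and bromo give, so this position still shows no step beyond the scatter in this assay.

From the compounds shown here alone, the true values of compound 2, compound 3 and compound 4 behind their limits remain open, and with them any order among the three halogens. Also open, going by these compounds, is whether an amine or a carboxylic acid on this carbon would give a number that can be read against compound 1 beyond the scatter.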